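Cytotoxicity of Three Variants Sharing One Core

The compounds below may be only part of what the source reports. "The series", "measured", "known", "first", "only" and "open" are said of these compounds alone.

Compound 1 `COc1ccc(S(=O)(=O)N(CC(N)=O)c2ccc(N(CC(N)=O)S(=O)(=O)c3ccc(SCCN=C=S)cc3)c3ccccc23)cc1`: > 10000 nM
Compound 2 `COc1ccc(S(=O)(=O)N(CC(N)=O)c2ccc(N(CC(N)=O)S(=O)(=O)c3ccc(SCCCN=C=S)cc3)c3ccccc23)cc1`: > 10000 nM

Of the compounds shown here, two have been tested in an ADME assay on cells (Peritoneal macrophage, Mus musculus) for cytotoxicity, read by CCK-8 assay, with a stated time of 24 h; on this read-out higher numbers stand for lower toxicity in this test and lower numbers for higher toxicity in this test. For compound 1 the value > 10000 nM is a limit of the assay, not a number. For compound 2 the value > 10000 nM is likewise a limit. Among the compounds with values here, the single step between them, a step that the two limits leave unreadable from compound 1 to compound 2, therefore cannot be read, since (the limit of > 10000 nM in this assay, at which 2 of the 2 values shown sit). Within the data shown here, compound 2 thus stands at the limit with no measured step to rank it.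

Compound 3 `COc1ccc(S(=O)(=O)N(CC(N)=O)c2ccc(N(CC(N)=O)S(=O)(=O)c3ccc([S+]([O-])CCCCN=C=S)cc3)c3ccccc23)cc1` differs from compound 2 by a group of 9 heavy atoms (5 carbon, 1 nitrogen, 1 oxygen, 2 sulfur; no ring) in place of a group of 7 heavy atoms (4 carbon, 1 nitrogen, 2 sulfur; no ring), on an aromatic carbon. Among the measured compounds shown here, no measured step bears on this change, the one step available being unreadable. No shift beyond the scatter can be foreseen in this assay, and compound 3 is expected to sit at the limit as well, with the step estimated as a step that the limit leaves unreadable from compound 2 to compound 3. Compound 3 is accordingly estimated at 15000 nM, within 5000 nM to 50000 nM.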

Compound 3, half-maximal cytotoxic concentration: > 10000 nM
Compound 3: a limit, no number; the forecaster's own chance of this, stated with the estimate: 80%; the middle value lies beyond the limit too.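

In this assay, within the data shown here, compound 3 also gives only a limit, so no step from compound 1 or compound 2 to compound 3 can be read: the limit of > 10000 nM in this assay, at which 3 of the 3 values shown sit.

The three compounds leave open how they rank against one another and at what concentration any of them becomes toxic to these cells.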